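The source may report more compounds than this note shows. Statements on the series, on what has been measured and on what is new or still open speak of the compounds shown alone.

Measured in a functional assay on U-937 cells (Homo sapiens) for antiproliferative activity, read by MTT assay, with a stated time of 72 h; on this read-out higher numbers stand for weaker inhibition and lower numbers for stronger inhibition:
- compound 1 `O=C(CCCCCCc1nc(-c2cccc([N+](=O)[O-])c2)no1)NO`: 1160 nM
- compound 2 `O=C(CCCCCCc1nc(-c2ccccc2)no1)C(F)(F)F`: 410 nM

Compound 2 holds the lower of the two numbers, and the gap to compound 1 lies beyond the scatter. Compound 3 `O=C(CCCCCCc1nc(-c2cccc([N+](=O)[O-])c2)no1)C(F)(F)F` differs from compound 2 by nitro in place of hydrogen on an aromatic carbon. Among the measured compounds shown here, no measured pair isolates this change, so the expectation is loose. In this assay, no shift beyond the scatter is expected, with a slight lean toward a higher number. The expected step is a 1.3-fold higher number from compound 2 to compound 3 (0.10 log units; within the scatter). For compound 3 the estimated value is 520 nM, with an expected range of 200 nM to 1350 nM.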

Compound 3, half-maximal inhibitory concentration: 560 nM
For compound 3 the middle estimate is 1.1-fold (0.03 log units) below the measured one; measured number inside the range.
By their numbers in this assay, from the lowest: compounds 2 and 3 (each within the scatter of the next); then compound 1.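

In this assay, nitro in place of hydrogen on an aromatic carbon, meta to a large group, gives a 1.4-fold higher number from compound 2 to compound 3 (0.14 log units; within the scatter), so with trifluoromethyl on the carbonyl carbon this position accepts nitro without a shift beyond the scatter. Among the compounds shown here, with nitro held constant, trifluoromethyl in place of hydroxyamino on a carbonyl carbon gives a 2.1-fold lower number from compound 1 to compound 3 (0.32 log units; beyond the scatter), the first single-place change here to pass the scatter. No measurement on hand explains either step.

Going by these compounds, whether an amine or a carboxylic acid at this position would also stay within the scatter remains open. Also open, on these data alone, is whether a longer chain would preserve the step between the two carbonyl substituents.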